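A few compounds are considered here, and "the series" means these few. Any claim that something is new, unique, unknown or untested is made for them only; others in the source may bear on it.

Measured compounds:
compound 1 `CC1=CC[C@H](C(C)C)c2cc(C)c(OC(=O)c3ccc(Cl)cc3)cc21`: 79.7%
compound 2 `Cc1cc2c(C(C)C)ccc(C)c2cc1OC(=O)c1ccc(C(F)(F)F)cc1`: 16.8%

In a functional assay on MCF7 cells (Homo sapiens) for antiproliferative activity, read by sulforhodamine B assay, with a stated time of 48 h, tested at 50 uM (a lower number here means less inhibition, a higher number more inhibition at the concentration tested (going by the name of the read-out)), compound 1 gives 79.7%, the highest of the two numbers shown. Compound 2 gives 16.8%, a gap beyond the scatter, though the two share no single-point difference. Compound 3 `CC1=CC[C@H](C(C)C)c2cc(C)c(OC(=O)c3ccccc3)cc21` is not yet measured in this assay. It differs from compound 1 by hydrogen in place of chloro on an aromatic carbon. Among the compounds with values here, no measured step of this kind exists, so the expectation rests on the structural change alone. A moderate decrease is expected, a number 19.7 percentage points lower from compound 1 to compound 3 (beyond the scatter). Compound 3 is thus estimated at 60%, with a range from 30% to 85%.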

Compound 3, a percentage reported as inhibition, at one concentration (the size of the read-out at that concentration, not a potency): 60.7%
Compound 3: the middle estimate sits 0.7 percentage points below what was measured, within the range that was stated.
By their numbers in this assay, from the lowest: compound 2; then compound 3; then compound 1.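

In this assay, within the data shown here, the change from 4-chlorophenyl to phenyl gives the first single-point reading at this position, a number 19 percentage points lower from compound 1 to compound 3 (beyond the scatter) in this series. The chloro is thus not required for a sizeable read-out: without it, compound 3 still gives 60.7% at the one concentration tested. No measured evidence accompanies this step. On these data alone, whether a fluoro, a methoxy or an amine at this same place would match the chloro of compound 1 stays open. A single pair also leaves open whether the step holds on other cores.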